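Thiadiazole-fused series: direct aryl in place of benzyl

This account rests on a few compounds, and the source may have more. Where it says the series, first, only, none or still open, it means among the compounds named here.

Measured so far:
compound 1, `CCc1ccc(-c2nn3cc(-c4cccc(N)c4)nc3s2)cc1`, 22000 nM
compound 2, `C=C(Br)C(=O)Nc1cccc(-c2cn3nc(Cc4cccc(OC)c4)sc3n2)c1`, 3100 nM

In a functional assay on CCRF-CEM cells (Homo sapiens) for inhibition, read by cell counting, with a stated time of 3 days (a lower number here means a stronger inhibitor, a higher number a weaker inhibitor), compound 2 gives the lower of the two numbers; compound 1 sits higher, and that gap lies beyond the scatter. Among the compounds with values here, no step between two measured compounds that differ in one place is available, so nothing in the measured pair isolates the effect of a single change.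

Compound 3, `C=C(Br)C(=O)Nc1cccc(-c2cn3nc(-c4ccc(OC)c(OC)c4)sc3n2)c1`, has not been measured. It differs from compound 2 as follows: 3,4-dimethoxyphenyl in place of 3-methoxybenzyl on an aromatic carbon. Both measured compounds carry an aromatic ring at that site, only one through a methylene, so the data do not separate the two arrangements.

Within the data shown here, because compound 2 gives 3100 nM and no directly comparable step exists, the estimated step of a 1.0-fold lower number from compound 2 to compound 3 (0.01 log units; within the scatter) is expected to be small, in either direction, not clearly beyond the scatter. Compound 3 is therefore expected near 3000 nM, within 800 nM to 12000 nM.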

Compound 3, half-maximal inhibitory concentration: 380 nM
For compound 3 the middle estimate is 7.9-fold (0.90 log units) above the measured one; measured number outside the range, below it.
By their numbers in this assay, from the lowest: compound 3; then compound 2; then compound 1.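

In this assay, within the data shown here, the substituent on the aromatic carbon of the five-membered ring matters: 3,4-dimethoxyphenyl in place of 3-methoxybenzyl gives an 8.2-fold lower number from compound 2 to compound 3 (0.91 log units; beyond the scatter) in the first step that isolates a change at one place. That step removes the methylene link and adds a second methoxy together, so it belongs to the combined change and not to either part alone. No measured data bear on the reason for the step.

The compounds shown leave open which part carries the step, a question that 3-methoxyphenyl or 3,4-dimethoxybenzyl at this site would address. Also open, as far as these compounds go, is how the site responds to a longer chain between the two rings, or to an amine or a carboxylic acid on the aryl ring.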